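Replacing a tert-butyl with a second methyl at the nitrile carbon

A few compounds are considered here, and "the series" means these few. Any claim that something is new, unique, unknown or untested is made for them only; others in the source may bear on it.

Compound 1 `C#CCNC(=O)[C@H](CC(C)C)NC(=O)N1CCOCC1`: 97000 nM
Compound 2 `CC(C)C[C@H](NC(=O)N1CCOCC1)C(=O)N[C@@H](C)C#N`: 142 nM
Compound 3 `CC(C)C[C@H](NC(=O)N1CCOCC1)C(=O)N[C@H](C#N)C(C)(C)C`: 107000 nM

In an assay for inhibition of cathepsin S (Homo sapiens) (on this read-out lower numbers stand for stronger inhibition and higher numbers for weaker inhibition), compound 3 gives the highest of the three numbers. Its nearest neighbour is compound 1, and the two lie within the scatter of each other; compound 2 sits far away, with a 750-fold higher number from compound 2 to compound 3 (2.88 log units; beyond the scatter) separating them.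

Compound 4 `CC(C)C[C@H](NC(=O)N1CCOCC1)C(=O)NC(C)(C)C#N` is not yet measured. It differs from compound 3 in one place: 1-cyano-1-methylethyl in place of 1-cyano-2,2-dimethylpropyl on an amide-type nitrogen. In plain terms, the tert-butyl branch on the carbon that carries the nitrile is cut back to a methyl, while a second methyl is added on that same carbon, so the stereocentre disappears.

Going by the values given here, two measured steps bear on this. Putting a tert-butyl where compound 2 has a methyl gave a 750-fold higher number from compound 2 to compound 3 (2.88 log units; beyond the scatter), and exchanging propargyl for 1-cyanoethyl gave a 680-fold lower number from compound 1 to compound 2 (2.83 log units; beyond the scatter). Both say that what sits on this carbon matters greatly, and that a small substituent there goes with a low number. Compound 4 carries two methyls rather than one methyl or one tert-butyl, so a large drop from compound 3 is expected, though likely not all the way back to compound 2. The expected step is a 54-fold lower number from compound 3 to compound 4 (1.73 log units; beyond the scatter), giving an estimated 2000 nM for compound 4, within 300 nM to 20000 nM.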

Compound 4, half-maximal inhibitory concentration: 114 nM
For compound 4 the middle estimate is 18-fold (1.24 log units) above the measured one; measured number outside the range, below it.
By their numbers in this assay, from the lowest: compounds 4 and 2 (each within the scatter of the next); then compounds 1 and 3 (each within the scatter of the next).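

In this assay, the tert-butyl branch on the carbon that carries the nitrile proves to be the problem in compound 3, and exchanging 1-cyano-2,2-dimethylpropyl for 1-cyano-1-methylethyl gives a 940-fold lower number from compound 3 to compound 4 (2.97 log units; beyond the scatter). Two methyls on that carbon do as well as one, with a 1.2-fold lower number from compound 2 to compound 4 (0.10 log units; within the scatter), which lies within the scatter, so a defined stereocentre there is not needed for a low number, and the gain over propargyl is kept, with an 850-fold lower number from compound 1 to compound 4 (2.93 log units; beyond the scatter). No independent measurement is available to explain why one tert-butyl branch on this carbon raises the number so sharply while a second methyl leaves it in place.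

The compounds shown leave open how the number would respond to an ethyl or isopropyl group on the carbon that carries the nitrile, or to the two methyls being joined into a cyclopropane ring, so the point between methyl and tert-butyl where the number starts to climb remains unknown. Also open, as far as these compounds go, is how a carboxylic acid or a primary amide would compare with the nitrile on this carbon.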